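A few compounds are considered here, and "the series" means these few. Any claim that something is new, unique, unknown or untested is made for them only; others in the source may bear on it.

In a functional assay on K562 cells (Homo sapiens) for antiproliferative activity, with a stated time of 48 h (on this read-out higher numbers stand for an effect only at larger amounts of compound and lower numbers for an effect already at smaller amounts), compound 1 (`O=C(CCCCCCC(=O)Nc1cccc(F)c1)NO`) gives 2400 nM and compound 2 (`O=C(CCCCCCC(=O)Nc1ccc(C(F)(F)F)cc1)NO`) gives 2100 nM. Compound 2 therefore stands level with compound 1, as the two numbers lie within the usual scatter of each other and cannot be ranked. The next compound, compound 3 (`O=C(CCCCCCC(=O)Nc1ccc(Cl)cc1)NO`), is derived from compound 2 by one exchange: chloro in place of trifluoromethyl on an aromatic carbon of a six-membered aromatic ring of carbon only, para to a large group (chloro in place of trifluoromethyl on an aromatic carbon). Within the data shown here, compound 1 and compound 2 differ in more than one place, so no measured step speaks directly to this exchange. Among the measured compounds shown here, the only guide is that the two measured values sit close together, with compound 1 at 2400 nM and compound 2 at 2100 nM. On that limited basis, no shift beyond the scatter is expected in this assay. The estimated change is a 1.0-fold higher number from compound 2 to compound 3 (0.02 log units; within the scatter). For compound 3 the expected value is 2200 nM, with an estimated range from 1100 nM to 4500 nM.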

Compound 3, half-maximal effective concentration: 3300 nM
Compound 3: the middle estimate sits 1.5-fold (0.18 log units) below what was measured; the measured number falls inside the stated range.
By their numbers in this assay, from the lowest: compounds 2, 1 and 3 (each within the scatter of the next).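

Among these compounds, the exchange of trifluoromethyl for chloro, on an aromatic carbon para to a large group, gives the first direct reading at this position: in this assay it amounts to a 1.6-fold higher number from compound 2 to compound 3 (0.20 log units; within the scatter). At this place, then, a group of 4 heavy atoms (1 carbon, 3 fluorine) gives way to 1 chlorine with no shift that can be told apart from repeated measurement, so this single step gives no sign that the read-out responds to the exchange. Nothing on hand accounts for this result or ties it to any property of either group.

With only chloro and trifluoromethyl compared directly at this place, the compounds shown leave open whether an amine, a methoxy group or a carboxylic acid there would move the number beyond the scatter. They also leave open whether a longer chain in the shared core would do so, and whether the exchange of trifluoromethyl for chloro would read the same way on a different core.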